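Carbamate to Amine-Bearing Amide on a Shared Core

This account rests on a few compounds, and the source may have more. Where it says the series, first, only, none or still open, it means among the compounds named here.

Compound 1, `Cc1ccc(C2CN(C)Cc3c(N)cccc32)cc1`, in a functional assay on the whole organism for inhibition of sodium-dependent dopamine transporter (Mus musculus) (on this read-out higher numbers stand for an effect only at larger amounts of compound and lower numbers for an effect already at smaller amounts), gives about 22 mg/kg.
Compound 2, `CCCCOC(=O)Nc1cccc2c1CN(C)CC2c1ccccc1`, in this assay gives 12 mg/kg.

Of the compounds shown here, two have been measured so far, both in this assay. Compound 2 has the lowest of the two numbers, yet compound 1 sits so close that the gap lies within the usual scatter, so the two cannot be ranked against each other on this evidence. Within the data shown here, no pair of measured compounds differs in just one place, so no single structural step has yet been tied to a change in dose.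

The next compound, compound 3, `CCCCNCCC(=O)Nc1cccc2c1CN(C)CC2c1ccccc1`, is built from compound 2 by one change at the carbonyl carbon: 2-(butylamino)ethyl in place of butoxy on a carbonyl carbon. Nothing measured here speaks directly to such a swap, so the expectation rests only on compound 2 itself. The step of a 1.3-fold higher number from compound 2 to compound 3 (0.12 log units; within the scatter) is expected to be small, likely no larger than the scatter, and in the direction of a somewhat higher dose. For compound 3 in this assay the estimate is 16 mg/kg, with a range from 5 mg/kg to 50 mg/kg.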

Compound 3, dose for half-maximal effect: > 60 mg/kg
Compound 3: a limit, no number (the forecaster's own chance of this, stated with the estimate: 10%); at least 3.7-fold (0.57 log units) between middle value and limit.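

Putting 2-(butylamino)ethyl in place of butoxy on a carbonyl carbon, which turns the carbamate into an amine-bearing amide, gives an at least 5.0-fold higher number from compound 2 to compound 3 (0.69 log units; beyond the scatter) in this assay. Among these compounds, this is the first single change on the shared core tied to a shift beyond the scatter, and it shows that the group on this carbonyl carbon is not a free choice: here the new group moves the read-out towards an effect only at larger amounts of compound. In this assay compound 3 gives > 60 mg/kg, which is a limit of the assay and not a number, so the step has a floor but no known size, and it is the only such value among the compounds shown: the limit of > 60 mg/kg in this assay, at which 1 of the 3 values shown sits.

This one swap changes the link to the carbonyl and the chain together, so the compounds shown cannot tell whether the step comes from losing the butoxy oxygen or from gaining the amine in the chain. From the compounds shown here alone, a plain pentyl chain on the same carbonyl, with no amine, or a 2-(dimethylamino)ethyl group would pull those two parts apart, and how far the dose moves for either remains open.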